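This account rests on a few compounds, and the source may have more. Where it says the series, first, only, none or still open, it means among the compounds named here.

Of the compounds shown here, three in this set have been tested in a functional assay on A2780 cells (Homo sapiens) for antiproliferative activity, read by MTT assay, with a stated time of 48 h (on this read-out lower numbers stand for stronger inhibition and higher numbers for weaker inhibition), all built around a shared amide-linked amine side chain. Compound 1, `CNCC(=O)Nc1cc(OC)ccc1C(=O)c1ccc(OC)c2c1C=CC(C)(C)O2`, gives 1590 nM. Compound 2, `CCNCC(=O)Nc1cc(OC)ccc1C(=O)c1ccc(OC)c2c1C=CC(C)(C)O2`, differs from compound 1 only in one spot: methyl in place of hydrogen on a saturated chain carbon bound to an amine nitrogen. In this assay compound 2 gives 4090 nM. That change produced a 2.6-fold higher number from compound 1 to compound 2 (0.41 log units; beyond the scatter), so the added carbon made the compound somewhat weaker here.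

Compound 3, `C=C(c1ccc2c(c1)C=CC(C)(C)O2)c1ccc(OC)cc1NC(=O)CNC`, carries the same side chain on a different core; how the core of compound 3 differs from the core of compound 1 is not broken down here. In this assay compound 3 gives 320 nM, the lowest number of the three measured compounds, and its step to each of the others lies beyond the usual scatter.

Compound 4, `C=C(c1ccc2c(c1)C=CC(C)(C)O2)c1ccc(OC)cc1NC(=O)CNCC`, has not yet been measured. It relates to compound 3 exactly as compound 2 relates to compound 1: methyl in place of hydrogen on a saturated chain carbon bound to an amine nitrogen. The place of the change is the same in both pairs, so this is the same change made on a second core.

For the measured compounds named here, with only one earlier example to go on, the expectation is that compound 4 will show a step of about a 2.3-fold higher number from compound 3 to compound 4 (0.37 log units; beyond the scatter), a modest weakening in line with the one seen in compound 1 and compound 2 because a 2.6-fold higher number from compound 1 to compound 2 (0.41 log units; beyond the scatter). On that basis compound 4 is estimated at 750 nM, with a likely range from 350 nM to 1600 nM.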

Compound 4, half-maximal inhibitory concentration: 1870 nM
Beside the measured number, compound 4's estimate is 2.5-fold (0.40 log units) below it; the whole stated range lies below it.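

In this assay, going from methylamino to ethylamino on the core of compound 3 again gives a weaker compound, with a 5.8-fold higher number from compound 3 to compound 4 (0.77 log units; beyond the scatter), so the change points the same way on both cores. The two steps also agree in size as closely as measurements of this kind can show, and the larger second step should not be read as a real difference: the same change on two cores in this assay, a 2.6-fold higher number (0.41 log units; beyond the scatter) from compound 1 to compound 2 and a 5.8-fold higher number (0.77 log units; beyond the scatter) from compound 3 to compound 4, 2.3-fold (0.36 log units) apart, within the scatter of two such steps

This means the effect of the change carried over from one core to the other in these two pairs, so the first pair was a fair guide to the direction and rough size of the second. However, two pairs cannot show that the same would hold on any other core, and these numbers alone do not explain why the extra methyl weakens the compounds.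

The compounds shown stop at ethylamino, so it remains open whether a longer chain such as propylamino would weaken the compounds further, and whether a plain amino group would do better than methylamino. A branched group such as isopropylamino or a ring amine such as pyrrolidine at the end of the side chain is also an open question on either core.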